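Allyl in Place of Bromophenyl on the Ring Nitrogen

This account rests on a few compounds, and the source may have more. Where it says the series, first, only, none or still open, it means among the compounds named here.

Compound 1 `COc1ccc(Cc2nn(-c3ccccc3)c(=O)c3ccccc23)cc1OC` — in a functional assay on aorta with Alpha-1D adrenergic receptor (Rattus norvegicus) as the target (on this read-out higher numbers stand for an effect only at larger amounts of compound and lower numbers for an effect already at smaller amounts), compound 1 gives > 100000 nM
Compound 2 `C=CCn1nc(Cc2ccc(OC)cc2)c2ccccc2c1=O` — in this assay compound 2 gives "not determined" (no result reported)
Compound 3 `COc1ccc(Cc2nn(-c3ccc(Br)cc3)c(=O)c3ccccc23)cc1OC` — in this assay compound 3 gives > 100000 nM

Compound 3 stands at the edge of what this assay can report: its reading of > 100000 nM is a limit of the assay, not a number. Compound 1 likewise returns only a limit, > 100000 nM. For compound 2 no result was reported in this assay, the entry being "not determined" (no result reported). Among the compounds with values here, the only step between measured compounds, a step that the two limits leave unreadable from compound 1 to compound 3, cannot be sized, since both ends sit at the limit of > 100000 nM in this assay, at which 2 of the 3 values shown sit.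

Compound 4 `C=CCn1nc(Cc2ccc(OC)c(OC)c2)c2ccccc2c1=O` differs from compound 3 by allyl in place of 4-bromophenyl on an aromatic nitrogen. Within the data shown here, no measured step bears on this change: the single step available concerns a different position, and compound 2, the other allyl-bearing compound, carries no value. There is thus no evidence for any size of step in this assay in either direction, nor for one beyond the scatter. On these grounds compound 4 is expected to give 80000 nM in this assay, estimated within 10000 nM to 300000 nM. The implied step an at least 1.2-fold lower number from compound 3 to compound 4 (0.09 log units; that floor lies within the scatter) is an estimate carried by the limits alone, and a further limit rather than a number is the likelier outcome for compound 4.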

Compound 4, half-maximal effective concentration: 9800 nM
Estimate against measurement, compound 4: 8.2-fold (0.91 log units) above; the whole stated range lies above it.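

Allyl in place of 4-bromophenyl on the aromatic nitrogen gives an at least 10-fold lower number from compound 3 to compound 4 (1.00 log units; beyond the scatter) in this assay, and allyl in place of phenyl on the same nitrogen gives an at least 10-fold lower number from compound 1 to compound 4 (1.00 log units; beyond the scatter) as well. This makes the substituent on that nitrogen the only place shown where a change can be read, and compound 4 is the only compound here with a number, whereas the bromo change on the phenyl ring cannot be read. Both steps are floors and not sizes, and the real gaps may be wider, because compound 1 and compound 3 each return only a limit: the limit of > 100000 nM in this assay, at which 2 of the 4 values shown sit.

Going by these compounds, whether the steps depend on the double bond of the allyl group or on the loss of the aromatic ring from that nitrogen stays open, as does how a saturated propyl chain, a longer chain or a chain ending in an amine would read there. On these data alone, what the second methoxy group of compound 4 contributes also stays open.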